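The source may report more compounds than this note shows. Statements on the series, on what has been measured and on what is new or still open speak of the compounds shown alone.

Working notes on the series in an ADME assay on Vero cells (Chlorocebus sabaeus) for cytotoxicity; a lower number here means that less compound is tolerated, a higher number that more compound is tolerated. Compound 1 (`CC(=O)c1c(NC(C)C)[nH]c2c(C(F)(F)F)cc(Cl)cc2c1=O`) reads > 25000 nM as a limit of the assay, not a number. Compound 2 (`CC(=O)c1c(Nc2ccc(F)cc2F)[nH]c2c(F)cc(F)cc2c1=O`) reads > 25000 nM as a limit too. Compound 3 (`CC(=O)c1c(N2CCCCC2)[nH]c2c(F)cc(F)cc2c1=O`) reads > 25000 nM as a limit as well, so it has no number of its own. All three therefore stand together at the limit of > 25000 nM in this assay, at which 3 of the 3 values shown sit, in this series.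

Compound 4 (`CCCCNc1[nH]c2c(F)cc(F)cc2c(=O)c1C(C)=O`) carries butylamino in place of piperidin-1-yl on an aromatic carbon, next to the ring nitrogen and ortho to the acetyl group (butylamino in place of piperidin-1-yl on an aromatic carbon). For the measured compounds named here, no measured pair differs in one place only, so the size of this change cannot be read directly. Due to the limit of > 25000 nM in this assay, at which 3 of the 3 values shown sit, across three different groups at this place, no change beyond the usual scatter is expected in this assay for compound 4. The estimated step is a step that the limit leaves unreadable from compound 3 to compound 4 in size. Compound 4 is estimated at 30000 nM, with an expected range of 14000 nM to 60000 nM, and a reading at the limit is the likeliest outcome.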

Compound 4, half-maximal cytotoxic concentration: > 25000 nM
Compound 4: only a limit was reported (the forecaster's own chance of this, stated with the estimate: 75%); the middle value lies beyond the limit too.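

In this assay compound 4 gives > 25000 nM, a limit and not a number, so the steps to it from compound 2 and compound 3 cannot be read: the limit of > 25000 nM in this assay, at which 4 of the 4 values shown sit. The compounds shown leave open whether any change of group shifts the read-out in this assay at all.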